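The source may hold more compounds than are shown below. What is called first, only, known or untested is meant among the compounds shown, and "the series" means these compounds.

Compound 1 `Cc1ccc2c(NCc3ccc(NC(=O)C4CCN(Cc5ccccc5F)CC4)cc3)nc(N(C)C)nc2c1` is one of two compounds in this study that were tested in a functional assay on SV5A8 cells (Homo sapiens) for cytotoxicity; a lower number here means a stronger inhibitor, a higher number a weaker inhibitor. In this assay compound 1 gives only a limit of > 6670 nM, not a number. The other tested compound, compound 2 `CCNc1nc(NCc2ccc(NC(=O)C3CCN(Cc4ccccc4)CC3)cc2)c2ccc(C)cc2n1`, also shows only a limit in this assay, namely > 2140 nM. Both values are therefore limits, one sitting at the limit of > 6670 nM in this assay, at which 1 of the 2 values shown sits, and the other at the limit of > 2140 nM in this assay, at which 1 of the 2 values shown sits, so compound 1 cannot be placed above or below compound 2 on the numbers shown, and no step between measured compounds is available.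

Compound 3 `Cc1ccc2c(NCc3ccc(NC(=O)C4CCN(Cc5ccc(Cl)cc5)CC4)cc3)nc(N(C)C)nc2c1` has not been measured. It differs from compound 1 by 4-chlorophenyl in place of 2-fluorophenyl on a saturated chain carbon bound to an amine nitrogen in a ring. Within the data shown here, with both measured compounds giving only limits, no measured step indicates that this kind of change shifts the read-out, and the step from compound 1 to compound 3 is expected to be a step that the limit leaves unreadable from compound 1 to compound 3, that is, none beyond the scatter. Compound 3 is thus expected to give about 9000 nM in this assay, within a range from 3000 nM to 30000 nM, most likely again as a limit rather than a number.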

Compound 3, half-maximal inhibitory concentration: > 3180 nM
Compound 3: no number, only a limit (the forecaster's own chance of this, stated with the estimate: 80%); the middle value lies beyond the limit too.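

In this assay compound 3 gives only a limit, > 3180 nM, and compound 1 also gives only a limit, so the step from compound 1 to compound 3 cannot be read. The compounds shown leave open whether 4-chlorophenyl in place of 2-fluorophenyl changes the read-out at all, and what number any of the three compounds would give.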